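The source may report more compounds than this note shows. Statements on the series, on what has been measured and on what is new or still open speak of the compounds shown alone.

Measured so far:
compound 1, `O=C1O[C@H]([C@@H](O)Cn2cc(CNS(=O)(=O)c3ccc(Cl)cc3F)nn2)C(OCc2ccccc2)=C1OCc1ccccc1` — 3390 nM
compound 2, `O=C1O[C@H]([C@@H](O)Cn2cc(CNS(=O)(=O)c3ccc(F)cc3)nn2)C(OCc2ccccc2)=C1OCc1ccccc1` — 26800 nM
compound 3, `COc1ccccc1-c1cn(C/C=C2\OC(=O)C(OCc3ccccc3)=C2OCc2ccccc2)nn1` — a limit only, > 100000 nM

In a functional assay on MCF7 cells (Homo sapiens) for antiproliferative activity, read by MTT assay, with a stated time of 72 h (on this read-out lower numbers stand for stronger inhibition and higher numbers for weaker inhibition), compound 2 gives 26800 nM, the highest of the two measured numbers. Going by the values given here, the single measured step, a 7.9-fold higher number from compound 1 to compound 2 (0.90 log units; beyond the scatter), concerns only the ring on the sulfonyl sulfur. For compound 3 this assay reports a limit, > 100000 nM, not a number.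

Compound 4, `CCCCCc1ccc(-c2cn(C[C@H](O)[C@H]3OC(=O)C(OCc4ccccc4)=C3OCc3ccccc3)nn2)cc1`, differs from compound 2 by 4-pentylphenyl in place of (((4-fluorophenyl)sulfonyl)amino)methyl on an aromatic carbon. The measured step from compound 1 to compound 2 does not cover so large an exchange, so no direct guide exists. The step of a 1.3-fold higher number from compound 2 to compound 4 (0.12 log units; within the scatter) is therefore expected to be small and uncertain, with a real chance that only a limit is reported. Compound 4 is estimated to give 35000 nM, within 8000 nM to 100000 nM.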

Compound 4, half-maximal inhibitory concentration: 9010 nM
Compound 4: the middle estimate sits 3.9-fold (0.59 log units) above what was measured; the measured number falls inside the stated range.
By their numbers in this assay, from the lowest: compound 1; then compound 4; then compound 2. At a limit, above all of these: compound 3.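

In this assay, 4-pentylphenyl in place of (((4-fluorophenyl)sulfonyl)amino)methyl gives a 3.0-fold lower number from compound 2 to compound 4 (0.47 log units; beyond the scatter). This aromatic carbon of the five-membered ring therefore tolerates a group with no sulfonyl sulfur, and activity here does not depend on the hydrogen-bond donor or acceptors of the group that leaves. Nothing measured here explains why the number falls. Going by these compounds, it remains open how much the pentyl chain itself contributes, since a shorter chain such as ethyl, or an amine at the end of the chain, would test that.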